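Working notes on alpha-2C intrinsic activity: compound 2 to 4

This account rests on a few compounds, and the source may have more. Where it says the series, first, only, none or still open, it means among the compounds named here.

Measured so far in an assay on CHO cells with Alpha-2C adrenergic receptor (Homo sapiens) as the target; on this read-out lower numbers stand for smaller maximal responses and higher numbers for larger maximal responses:
- compound 1 `C=COc1ccccc1OC(C)C1=NCCN1`: 0.48
- compound 2 `CCc1ccccc1OC(C)C1=NCCN1`: 0.6
- compound 3 `C=CCc1cccc(CC=C)c1OC(C)C1=NCCN1`: 0.9

In this assay compound 2 stands second highest of the three numbers. Its nearest neighbour is compound 1, whose value 0.48 lies a step below it (a number 0.12 higher from compound 1 to compound 2 (beyond the scatter)); the furthest is compound 3 with 0.9, which lies well beyond the scatter above compound 2.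

Compound 4 `CC(Oc1ccccc1S(C)(=O)=O)C1=NCCN1` differs from compound 2 in one place: methylsulfonyl in place of ethyl on an aromatic carbon. Among the compounds with values here, the one measured step at this aromatic carbon, a number 0.12 higher from compound 1 to compound 2 (beyond the scatter), concerns ethyl in place of vinyloxy; no measured step shows methylsulfonyl entering, so the single-step evidence does not carry over. Compound 1 and compound 2 together only show that substituents at this position move the maximal response by modest amounts in this assay.

For compound 4 the estimate in this assay is therefore 0.5, with a range of 0.3 to 0.75. This expected step, a number 0.10 lower from compound 2 to compound 4 (within the scatter), would be a small shift downward, with wide uncertainty in both directions.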

Compound 4, intrinsic activity: the largest response reached, as a fraction of the reference agonist's: 0.6
The estimate for compound 4 lay 0.10 below the measured number; low and high end bracket the measured number.
By their numbers in this assay, from the lowest: compound 1; then compounds 2 and 4 (each within the scatter of the next); then compound 3.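

In this assay the read-out does not separate methylsulfonyl from ethyl on this aromatic carbon: no change at the digits printed from compound 2 to compound 4 (within the scatter) is the step, even though methylsulfonyl is the larger group and carries hydrogen-bond acceptors that ethyl lacks. Methylsulfonyl also gives a number 0.12 higher from compound 1 to compound 4 (beyond the scatter) in place of vinyloxy, which matches the size of a number 0.12 higher from compound 1 to compound 2 (beyond the scatter) and leaves vinyloxy as the only one of these three groups set apart, by a modest step. No supporting measurement bears on why these groups compare as they do.

On these data alone, whether this insensitivity holds for a carboxylic acid, an amine or a longer chain at the same carbon stays open. Also open, as far as these compounds go, is whether methylsulfonyl would behave the same way alongside the second allyl-bearing pattern of compound 3 in this assay on the shared core.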